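Trading methoxy groups for a single hydroxyl on the arylidene

The source may hold more compounds than are shown below. What is called first, only, known or untested is meant among the compounds shown, and "the series" means these compounds.

Compound 1 `COc1ccc(/C=C2/N=C(c3ccccc3)N(c3ccc4oc(-c5ccccc5)cc(=O)c4c3)C2=O)cc1` gives 21.7 ug/mL in a functional assay on MDA-MB-435 cells (Homo sapiens) for inhibition, read by sulforhodamine B assay (a lower number here means a stronger inhibitor, a higher number a weaker inhibitor), and compound 2 `O=C1/C(=C\c2ccc(Cl)c(Cl)c2)N=C(c2ccccc2)N1c1ccc2oc(-c3ccccc3)cc(=O)c2c1` gives 20.2 ug/mL. Compound 3 `COc1ccc(/C=C2/N=C(c3ccccc3)N(c3ccc4oc(-c5ccccc5)cc(=O)c4c3)C2=O)cc1OC` gives 12 ug/mL in this assay, the lowest of the three numbers, though neither gap reaches beyond the scatter: the step of a 1.7-fold lower number from compound 2 to compound 3 (0.23 log units; within the scatter) and the step of a 1.8-fold lower number from compound 1 to compound 3 (0.26 log units; within the scatter) are both small. Compound 4 `O=C1/C(=C\c2ccc(O)cc2)N=C(c2ccccc2)N1c1ccc2oc(-c3ccccc3)cc(=O)c2c1` differs from compound 3 by 4-hydroxyphenyl in place of 3,4-dimethoxyphenyl on a double-bonded chain carbon bound to a double-bonded ring carbon. The relevant steps are those that vary this same aryl group, a 1.1-fold lower number from compound 1 to compound 2 (0.03 log units; within the scatter) and a 1.7-fold lower number from compound 2 to compound 3 (0.23 log units; within the scatter), and both stayed within the scatter. No step beyond the scatter is therefore expected in this assay, with at most a drift toward a somewhat higher number. Compound 4 is estimated at 18 ug/mL, between 9 ug/mL and 36 ug/mL, a step of a 1.5-fold higher number from compound 3 to compound 4 (0.18 log units; within the scatter).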

Compound 4, half-maximal inhibitory concentration: 21.4 ug/mL
Beside the measured number, compound 4's estimate is 1.2-fold (0.08 log units) below it, and the stated range covers the measured number.
By their numbers in this assay, from the lowest: compounds 3, 2, 4 and 1 (each within the scatter of the next).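

With a hydrogen-bond donor entering on the double-bonded chain carbon, this assay still shows no step beyond the scatter against any of the three earlier aryl groups: a 1.8-fold higher number from compound 3 to compound 4 (0.25 log units; within the scatter), a 1.1-fold higher number from compound 2 to compound 4 (0.03 log units; within the scatter), and a 1.0-fold lower number from compound 1 to compound 4 (0.01 log units; within the scatter). The last step shows that hydrogen in place of methyl on this oxygen is equally unresolved. No available evidence bears on this result. The compounds shown leave open whether an amine or a carboxylic acid on this aryl group would give a step beyond the scatter.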